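Working notes: sulfonyl to benzyl exchange on a ring nitrogen

A few compounds are considered here, and "the series" means these few. Any claim that something is new, unique, unknown or untested is made for them only; others in the source may bear on it.

Measured so far in a functional assay on SGC-7901 cells (Homo sapiens) for cytotoxicity, read by MTT assay, with a stated time of 48 h; on this read-out higher numbers stand for weaker inhibition and lower numbers for stronger inhibition:
Compound 1 `CCN(CC)c1ccc2cc(C(=O)c3ccc(N4CCN(C(=O)CN5CCN(S(=O)(=O)c6ccc(C#N)cc6)CC5)CC4)cc3)oc2c1` gives > 40000 nM, which is a limit of the assay and not a number.
Compound 2 `CCN(CC)c1ccc2cc(C(=O)c3ccc(N4CCN(C(=O)CN5CCN(S(=O)(=O)c6ccc(F)cc6)CC5)CC4)cc3)oc2c1` gives > 40000 nM, likewise a limit.

Compound 2 therefore stands at the limit, as does every value shown so far (the limit of > 40000 nM in this assay, at which 2 of the 2 values shown sit). Within the data shown here, the only measured step, a step that the two limits leave unreadable from compound 1 to compound 2, runs between two limits and has no readable size.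

Compound 3 `CCN(CC)c1ccc2cc(C(=O)c3ccc(N4CCN(C(=O)CN5CCN(Cc6ccc(C(F)(F)F)cc6)CC5)CC4)cc3)oc2c1` differs from compound 2 by 4-(trifluoromethyl)benzyl in place of (4-fluorophenyl)sulfonyl on an amine nitrogen in a ring. Among the measured compounds shown here, no measured step touches this position: the one step available, a step that the two limits leave unreadable from compound 1 to compound 2, changes a group on an aromatic carbon and stays unreadable. The measured set thus sets no direction or size for the step in this assay. Since both measured compounds sit at the limit (the limit of > 40000 nM in this assay, at which 2 of the 2 values shown sit), the expectation is that compound 3 most likely returns a limit as well, with only a modest chance of a readable number.

The estimate for compound 3 in this assay is 40000 nM, with a range from 12000 nM to 120000 nM. The expected step is a number no higher from compound 2 to compound 3 (the limit leaves the size open).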

Compound 3, half-maximal inhibitory concentration: 32000 nM
The estimate for compound 3 lay 1.3-fold (0.10 log units) above the measured number; low and high end bracket the measured number.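

In this assay, among these compounds, compound 3 gives 32000 nM, the first value in this set that is not a limit, and it comes with the exchange on the amine nitrogen in a ring, not with a change of group on the aromatic carbon of the sulfonyl substituent. The exchange gives an at least 1.2-fold lower number from compound 2 to compound 3 (0.09 log units; that floor lies within the scatter), and with the nitrile-bearing sulfonyl compound as the start it gives an at least 1.2-fold lower number from compound 1 to compound 3 (0.09 log units; that floor lies within the scatter), so neither step is shown to go beyond the usual scatter and the true size of the exchange stays open. The step between the two sulfonyl compounds cannot be read, and limits still make up most of the set: the limit of > 40000 nM in this assay, at which 2 of the 3 values shown sit.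

As far as these compounds go, it remains open whether a plain benzyl or a 4-fluorobenzyl on the same nitrogen would also give a readable number, which would separate the role of the benzyl link from that of the trifluoromethyl group. Also open, from the compounds shown here alone, is how the value would respond to an acetyl group or a longer alkyl chain on this nitrogen, or to a carboxylic acid or an amine in place of trifluoromethyl on the benzyl ring.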